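The source may report more compounds than this note shows. Statements on the series, on what has been measured and on what is new or still open speak of the compounds shown alone.

Within the data shown here, the two compounds measured so far share one core and differ only in the aromatic group attached to a saturated ring carbon. Compound 1 `Cc1ccccc1C1(CNC(=O)Nc2c(C(C)C)cccc2C(C)C)CCCC1` carries a 2-methylphenyl there, and in an assay on microsomes for inhibition of acyl-CoA:cholesterol acyltransferase (Oryctolagus cuniculus) (on this read-out lower numbers stand for stronger inhibition and higher numbers for weaker inhibition), compound 1 gives 17 nM. Compound 2 `COc1cccc(C2(CNC(=O)Nc3c(C(C)C)cccc3C(C)C)CCCC2)c1` carries a 3-methoxyphenyl instead, and in this assay compound 2 gives 13 nM. The step of a 1.3-fold lower number from compound 1 to compound 2 (0.12 log units; within the scatter) is within the scatter, so compound 2 sits on a par with compound 1 rather than apart from it.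

Compound 3 `CC(C)c1cccc(C(C)C)c1NC(=O)NCC1(c2ccccc2C(F)(F)F)CCCC1` changes the same aromatic group once more: 2-(trifluoromethyl)phenyl in place of 3-methoxyphenyl on a saturated ring carbon. Among the measured compounds shown here, the only measured step that bears on this, the exchange of one aromatic group for another on that saturated ring carbon, is a 1.3-fold lower number from compound 1 to compound 2 (0.12 log units; within the scatter), which did not move the number beyond the scatter. For the measured compounds named here, no measured compound carries a trifluoromethyl group, so nothing in the data speaks to that group itself. The step of a 1.2-fold higher number from compound 2 to compound 3 (0.06 log units; within the scatter) is therefore expected to stay within the scatter. Compound 3 is expected to give 15 nM in this assay, with a range from 5 nM to 45 nM.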

Compound 3, half-maximal inhibitory concentration: 18 nM
Estimate against measurement, compound 3: 1.2-fold (0.08 log units) below; the range from low to high includes it.
By their numbers in this assay, from the lowest: compounds 2, 1 and 3 (each within the scatter of the next).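

Among these compounds, compound 3 brings a trifluoromethyl group into the series for the first time, and in this assay the exchange of the 3-methoxyphenyl for the 2-(trifluoromethyl)phenyl gives only a small step (a 1.4-fold higher number from compound 2 to compound 3 (0.14 log units; within the scatter)), so a third aromatic group on this saturated ring carbon sits on a par with the other two. The cleanest comparison is the one-group swap of trifluoromethyl in place of methyl on an aromatic carbon (a 1.1-fold higher number from compound 1 to compound 3 (0.02 log units; within the scatter)), which shows that this read-out does not tell these two groups apart here, even though one carries fluorine and the other only carbon and hydrogen. Nothing available explains why the three numbers stay so close.

All three compounds keep an uncharged aromatic ring of carbon only on this ring carbon, so the flat picture may hold only for groups of that kind. An amine or a carboxylic acid on that aromatic ring, or a plain hexyl chain in place of the ring, could still show how far this position really tolerates exchange.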